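The source may hold more compounds than are shown below. What is called first, only, known or untested is meant among the compounds shown, and "the series" means these compounds.

Working notes on the series.

The set comprises compound 1 `COc1ccc(/C=C/C(=O)Nc2cc3c(Nc4ccc(F)c(Cl)c4)ncnc3cc2OC)c(OC)c1`, compound 2 `O=C(/C=C/c1cccc(Cl)c1Cl)Nc1cc2c(Nc3ccc(F)c(Cl)c3)ncnc2cc1O[C@H]1CCOC1`, compound 3 `COc1ccc(OC)c(/C=C/C(=O)Nc2cc3c(Nc4ccc(F)c(Cl)c4)ncnc3cc2OC)c1` and, so far unmeasured, compound 4 `O=C(/C=C/c1ccc(F)cc1Cl)Nc1cc2c(Nc3ccc(F)c(Cl)c3)ncnc2cc1O[C@H]1CCOC1`. All four share the same core; they differ in the aryl group carried on the unsaturated chain of the amide and in the ether on the core. In a functional assay on HeLa cells (Homo sapiens) for cytotoxicity, read by MTT assay, with a stated time of 72 h (on this read-out lower numbers stand for stronger inhibition and higher numbers for weaker inhibition), compound 2 gives 30500 nM. Among the measured compounds shown here, this is the only number in the set: in this assay compound 1 gives "not determined" (no result reported) and compound 3 gives "not determined" (no result reported), so nothing can be said of their potency and no ordering among the measured compounds is possible.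

Compound 4 differs from compound 2 at a single place: 2-chloro-4-fluorophenyl in place of 2,3-dichlorophenyl on a double-bonded chain carbon bound to a double-bonded chain carbon. For the measured compounds named here, no step between two measured compounds is available to calibrate this change; with the rest of the molecule held constant, the halogen swap on the aryl group is expected to leave the read-out within the usual scatter of this assay rather than to shift it in a clear direction. On that basis compound 4 is estimated at 30000 nM, with a range from 12000 nM to 75000 nM, a step of a 1.0-fold lower number from compound 2 to compound 4 (0.01 log units; within the scatter) that is expected to be essentially nil.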

Compound 4, half-maximal inhibitory concentration: 37500 nM
Beside the measured number, compound 4's estimate is 1.3-fold (0.10 log units) below it, and the stated range covers the measured number.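

Among the compounds shown here, this is the first readable step at this place. In this assay, 2-chloro-4-fluorophenyl in place of 2,3-dichlorophenyl on a double-bonded chain carbon bound to a double-bonded chain carbon gives a 1.2-fold higher number from compound 2 to compound 4 (0.09 log units; within the scatter), so on this read-out the two halogen-bearing aryl groups cannot be told apart. Nothing available bears on why the two compounds read alike.

Steps to compound 1 and compound 3 cannot be read, so the effect of the ether on the core remains open. Also open, going by these compounds, is whether this place accepts groups other than halogen-bearing aryl rings, such as an aryl ring carrying an amine or a carboxylic acid, or a longer chain in place of the ethenyl link.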